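Swapping the Alkyne Terminus on a Shared Scaffold

A few compounds are considered here, and "the series" means these few. Any claim that something is new, unique, unknown or untested is made for them only; others in the source may bear on it.

Measured so far:
compound 1 `CNC(=O)[C@@]12C[C@@H]1[C@@H](n1cnc3c(NC)nc(C#Cc4ccc(F)cc4)nc31)[C@H](O)[C@@H]2O` gives 27%
compound 2 `CNC(=O)[C@@]12C[C@@H]1[C@@H](n1cnc3c(NC)nc(C#Cc4cccnn4)nc31)[C@H](O)[C@@H]2O` gives 11%
compound 3 `CNC(=O)[C@@]12C[C@@H]1[C@@H](n1cnc3c(NC)nc(C#Cc4cc(C)c(C)o4)nc31)[C@H](O)[C@@H]2O` gives 15%

Three compounds share one core and differ only in the group on the triple-bonded carbon. In an assay on CHO cells for displacement of a labelled ligand from adenosine receptor A1 (Homo sapiens), read by scintillation counting, with a stated time of 60 min, tested at 10 uM (on this read-out lower numbers stand for less inhibition and higher numbers for more inhibition at the one concentration tested (going by the name of the read-out)), compound 1 gives 27%, compound 2 gives 11% and compound 3 gives 15%. Compound 3 stands second highest of the three, but its gap to compound 2 is within the scatter, so the two cannot be ordered; only compound 1 is clearly apart, with a number 12 percentage points lower from compound 1 to compound 3 (beyond the scatter) and a number 16 percentage points lower from compound 1 to compound 2 (beyond the scatter) showing that exchanging 4-fluorophenyl for either ring lowers inhibition modestly, while a number 4 percentage points higher from compound 2 to compound 3 (within the scatter) is within the scatter.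

Compound 4 `CNC(=O)[C@@]12C[C@@H]1[C@@H](n1cnc3c(NC)nc(C#CC4CC4)nc31)[C@H](O)[C@@H]2O` is the next step: cyclopropyl in place of 4,5-dimethylfuran-2-yl on a triple-bonded carbon. Among the measured compounds shown here, no measured step covers a cyclopropyl on this carbon, so the only guide is that exchanging one terminal group for another of similar size has so far moved the read-out by at most a modest amount, and between the two non-phenyl groups not at all beyond the scatter. The step from compound 3 to compound 4 is therefore expected to be small, most likely within the scatter, as a number 1 percentage points lower from compound 3 to compound 4 (within the scatter). Compound 4 is estimated at 14%, with a range from 3% to 30%.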

Compound 4, a percentage reported as inhibition, at one concentration (the size of the read-out at that concentration, not a potency): 38%
For compound 4 the middle estimate is 24 percentage points below the measured one, and the stated range ends below it.
By their numbers in this assay, from the lowest: compounds 2 and 3 (each within the scatter of the next); then compound 1; then compound 4.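

In this assay the group on this triple-bonded carbon can raise the number as well as lower it: a number 23 percentage points higher from compound 3 to compound 4 (beyond the scatter) and a number 27 percentage points higher from compound 2 to compound 4 (beyond the scatter) show that cyclopropyl reads clearly higher than either 4,5-dimethylfuran-2-yl or pyridazin-3-yl. Cyclopropyl also passes the 4-fluorophenyl group, with a number 11 percentage points higher from compound 1 to compound 4 (beyond the scatter) making this the first exchange of 4-fluorophenyl shown here that raises the number rather than lowers it, so an aromatic ring at the end of the triple bond is not needed for the inhibition seen here, and a group with fewer heavy atoms can read higher. Nothing measured here explains the rise.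

Going by these compounds, the change from 4,5-dimethylfuran-2-yl to cyclopropyl removes the aromatic ring and reduces the heavy atoms together, so these compounds cannot separate the two, and it remains open what a cyclobutyl ring, a longer chain such as propyl, or an amine would do on this carbon. A reading at one concentration also leaves the actual potency of all four compounds open.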